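The compounds below may be only part of what the source reports. "The series", "measured", "known", "first", "only" and "open" are said of these compounds alone.

In a functional assay on K562 cells (Homo sapiens) for inhibition, read by thymidine incorporation, with a stated time of 48 h (on this read-out lower numbers stand for stronger inhibition and higher numbers for weaker inhibition), compound 1 `Clc1nc(C#Cc2ccccc2)c2ncn(Cc3ccccc3)c2n1` gives 0.12 ug/mL, compound 2 `C=Cc1ncnc2c1ncn2Cc1ccccc1` gives 1.1 ug/mL and compound 3 `Clc1nc(/C=C/c2ccccc2)c2ncn(Cc3ccccc3)c2n1` gives 2 ug/mL. Compound 3 therefore lies within the scatter of compound 2 and far from compound 1. Compound 4 `Nc1nc(/C=C/c2ccccc2)c2ncn(Cc3ccccc3)c2n1` differs from compound 3 in one place: amino in place of chloro on an aromatic carbon. Within the data shown here, the only measured single-place step, a 17-fold higher number from compound 1 to compound 3 (1.22 log units; beyond the scatter), was large, but it puts 2-phenylethenyl in place of 2-phenylethynyl and leaves the chloro untouched. Among the measured compounds shown here, no measured step covers this swap, so no change beyond the scatter is expected in this assay, and the estimated step is a 1.5-fold higher number from compound 3 to compound 4 (0.18 log units; within the scatter). For compound 4 the expected value is 3 ug/mL, with an estimated range of 0.8 ug/mL to 12 ug/mL.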

Compound 4, half-maximal inhibitory concentration: 1.2 ug/mL
The estimate for compound 4 lay 2.5-fold (0.40 log units) above the measured number, within the range that was stated.
By their numbers in this assay, from the lowest: compound 1; then compounds 2, 4 and 3 (each within the scatter of the next).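

In this assay, amino in place of chloro on this aromatic carbon, between two ring nitrogen atoms, gives a 1.7-fold lower number from compound 3 to compound 4 (0.22 log units; within the scatter). Among these compounds, this is the first step read at this position, and it shows that with the 2-phenylethenyl group in place, this swap moves the number no further than the scatter. Nothing measured here offers an explanation for this result. Open, going by these compounds, is whether a methoxy or dimethylamino group on this carbon would also stay within the scatter. Also open, on these data alone, is whether amino would do so alongside the 2-phenylethynyl group of compound 1.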